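The source may hold more compounds than are shown below. What is called first, only, known or untested is meant among the compounds shown, and "the series" means these compounds.

Measured so far:
- compound 1, `O=[N+]([O-])c1ccc(-c2nc3cc(C(F)(F)F)ccc3[nH]2)cc1`: 18000 nM
- compound 2, `CC(=O)Nc1ccc(-c2nc3cc(C(F)(F)F)ccc3[nH]2)cc1`: 53000 nM
- compound 3, `O=[N+]([O-])c1ccc(-c2nc3cc(Cl)c(Cl)cc3[nH]2)cc1`: only a limit in this assay

The read-out in an ADME assay on BHK cells (Mesocricetus auratus) for cytotoxicity, read by MTT assay, with a stated time of 96 h (on this read-out higher numbers stand for lower toxicity in this test and lower numbers for higher toxicity in this test), is what matters here. Compound 1 gives 18000 nM in this assay, and compound 2 gives 53000 nM. The change acetamido in place of nitro on an aromatic carbon produced the step of a 2.9-fold higher number from compound 1 to compound 2 (0.47 log units; beyond the scatter). For compound 3 this assay gives only a limit, > 100000 nM, as noted in the limit of > 100000 nM in this assay, at which 1 of the 3 values shown sits. The difference between the cores of compound 1 and compound 3 is not broken down here.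

Compound 4, `CC(=O)Nc1ccc(-c2nc3cc(Cl)c(Cl)cc3[nH]2)cc1`, has not yet been measured. It differs from compound 3 by acetamido in place of nitro on an aromatic carbon, the same change seen from compound 1 to compound 2. The step that the limit leaves unreadable from compound 3 to compound 4 is expected to be of similar size to a 2.9-fold higher number from compound 1 to compound 2 (0.47 log units; beyond the scatter), resting on that earlier step. Compound 4 is therefore estimated at 200000 nM, expected between 60000 nM and 600000 nM, most likely again reported only as a limit.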

Compound 4, half-maximal cytotoxic concentration: > 100000 nM
Compound 4 was reported as a limit; the forecaster's own chance of this, stated with the estimate: 80%; the middle value lies beyond the limit too.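

Compound 3 and compound 4 are both reported only as limits, so no step between them can be read: the limit of > 100000 nM in this assay, at which 2 of the 4 values shown sit.

The compounds shown leave open whether acetamido in place of nitro changes the number with the core of compound 3 as it does with the core of compound 1.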